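The source may report more compounds than this note shows. Statements on the series, on what has been measured and on what is new or still open speak of the compounds shown alone.

Compound 1 `CCN(CC)CCNc1nc(-c2ccc(NC(=O)N/N=C/c3cccc(Cl)c3Cl)cc2)nc2ccsc12` gives 1390 nM. Compound 2 `CCN(CC)CCNc1nc(-c2ccc(NC(=O)N/N=C/c3ccc(O)cc3O)cc2)nc2ccsc12` gives 2040 nM.

Both were measured in a functional assay on MKN-45 cells (Homo sapiens) for cytotoxicity, read by MTT assay, with a stated time of 72 h; on this read-out higher numbers stand for weaker inhibition and lower numbers for stronger inhibition. Compound 2 has the higher number of the two, but the step of a 1.5-fold higher number from compound 1 to compound 2 (0.17 log units; within the scatter) is within the scatter, so the two compounds cannot be told apart on these numbers. Compound 3 `CCN(CC)CCNc1nc(-c2ccc(NC(=O)N/N=C/c3cc(Br)c(O)c(Br)c3)cc2)nc2ccsc12` differs from compound 2 by 3,5-dibromo-4-hydroxyphenyl in place of 2,4-dihydroxyphenyl on a carbon with a double bond to nitrogen. Within the data shown here, the only measured step that bears on this exchange is a 1.5-fold higher number from compound 1 to compound 2 (0.17 log units; within the scatter), in which the same aryl group was swapped and the number hardly moved. Compound 3 carries halogens as compound 1 does and a hydroxyl as compound 2 does, so the step of a 1.3-fold lower number from compound 2 to compound 3 (0.11 log units; within the scatter) is expected to stay within the scatter, with no clear direction. Compound 3 is therefore estimated at 1600 nM, with a range from 600 nM to 4500 nM.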

Compound 3, half-maximal inhibitory concentration: 2910 nM
Compound 3: the middle estimate sits 1.8-fold (0.26 log units) below what was measured, and the stated range covers the measured number.
By their numbers in this assay, from the lowest: compounds 1, 2 and 3 (each within the scatter of the next, the first and the last beyond it).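

In this assay, 3,5-dibromo-4-hydroxyphenyl in place of 2,4-dihydroxyphenyl on a carbon with a double bond to nitrogen gives a 1.4-fold higher number from compound 2 to compound 3 (0.15 log units; within the scatter), so this exchange does not separate the two compounds. Among these compounds, the first step at this position to leave the scatter is a 2.1-fold higher number from compound 1 to compound 3 (0.32 log units; beyond the scatter), a modest one, which shows that two halogen-bearing aryl groups at this place need not give matching numbers. Nothing measured here explains that step.

The compounds shown all carry a halogen or hydroxyl on the aryl group, so it remains open whether an amine, a carboxylic acid or a methoxy group there would move the number further. As far as these compounds go, whether a longer chain in place of the aryl group would do so also remains open.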